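Cyclopentylsulfanyl for benzyloxy: cytotoxicity in Akata cells

The source may report more compounds than this note shows. Statements on the series, on what has been measured and on what is new or still open speak of the compounds shown alone.

Compound 1 `CC(C)CNc1nc(N)nc2c1ncn2/C=C1/CC1(CO)CO` gives > 24000 nM in an ADME assay on Akata cells (Homo sapiens) for cytotoxicity, with a stated time of 7 days (on this read-out lower numbers stand for higher toxicity in this test and higher numbers for lower toxicity in this test), a limit rather than a number.
Compound 2 `Nc1nc(OCc2ccccc2)c2ncn(/C=C3/CC3(CO)CO)c2n1` gives > 20000 nM in this assay, again a limit.

Compound 2 thus stands only at a limit, and both values shown are limits the limit of > 20000 nM in this assay, at which 1 of the 2 values shown sits (the limit of > 24000 nM in this assay, at which 1 of the 2 values shown sits). Within the data shown here, the one measured step, a step that the two limits leave unreadable from compound 1 to compound 2, is unreadable because both of its ends are limits the limit of > 24000 nM in this assay, at which 1 of the 2 values shown sits (the limit of > 20000 nM in this assay, at which 1 of the 2 values shown sits). Compound 3 `Nc1nc(SC2CCCC2)c2ncn(/C=C3/CC3(CO)CO)c2n1` differs from compound 2 by cyclopentylsulfanyl in place of benzyloxy on an aromatic carbon. No readable step bears on this change, so in this assay no step beyond the scatter is expected, and compound 3 is expected to remain at a limit. Compound 3 is estimated at 30000 nM, between 15000 nM and 100000 nM. The expected step is a step that the limit leaves unreadable from compound 2 to compound 3.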

Compound 3, half-maximal cytotoxic concentration: > 20000 nM
Compound 3: only a limit was reported; the forecaster's own chance of this, stated with the estimate: 85%; the middle value does not contradict the limit.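

Compound 3 gives > 20000 nM in this assay, again a limit, and its steps from compound 1 and compound 2 cannot be read. The compounds shown leave open whether exchanging the group on the aromatic carbon changes toxicity in this assay at all.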